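A few compounds are considered here, and "the series" means these few. Any claim that something is new, unique, unknown or untested is made for them only; others in the source may bear on it.

Working notes on the series. Among the compounds with values here, compound 1 `CN1CCC[C@H]1COc1cccnc1` gives 0.15 nM in an assay on membranes from brain for displacement of a labelled ligand from Neuronal acetylcholine receptor; alpha4/beta2 (Rattus norvegicus) (on this read-out lower numbers stand for stronger inhibition and higher numbers for weaker inhibition), and stands highest of the two numbers so far; compound 2 `CCCc1cncc(OC[C@@H]2CCCN2C)c1` gives 0.12 nM in this assay, a change described by a 1.3-fold lower number from compound 1 to compound 2 (0.10 log units; within the scatter). Compound 3 `CN1CCC[C@H]1COc1ccc(Br)nc1` is unmeasured; it differs from compound 1 by bromo in place of hydrogen on an aromatic carbon. Within the data shown here, the only measured step, the propyl addition, lies within the scatter and is a different change, so it offers little guidance here. For compound 3 a step of about a 1.3-fold higher number from compound 1 to compound 3 (0.12 log units; within the scatter) is expected, that is no shift beyond the scatter. Compound 3 is estimated at 0.2 nM, with a range of 0.06 nM to 0.7 nM.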

Compound 3, inhibition constant: 1.91 nM
Compound 3: the middle estimate sits 9.6-fold (0.98 log units) below what was measured; measured number above the stated range.
By their numbers in this assay, from the lowest: compounds 2 and 1 (each within the scatter of the next); then compound 3.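

In this assay, within the data shown here, bromo in place of hydrogen on the aromatic carbon next to the ring nitrogen gives a 13-fold higher number from compound 1 to compound 3 (1.10 log units; beyond the scatter), the first step beyond the scatter. This carbon therefore does not accept every replacement of hydrogen without a loss, whereas propyl at another ring carbon gave only a 1.3-fold lower number from compound 1 to compound 2 (0.10 log units; within the scatter). Nothing on hand accounts for the loss.

From the compounds shown here alone, whether it belongs to bromo itself or to any group on this carbon stays open. Fluoro, chloro, methyl or an amine there would separate these readings.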